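Methoxy to isopropyl on the aryl carbonyl: expected shift

The source may report more compounds than this note shows. Statements on the series, on what has been measured and on what is new or still open speak of the compounds shown alone.

Values in an assay on THP-1 cells for antagonist activity at P2X purinoceptor 7 (Homo sapiens), read by ELISA, with a stated time of 30 min; on this read-out higher numbers stand for weaker inhibition and lower numbers for stronger inhibition:
- compound 1 `N#Cc1cccc(S(=O)(=O)Oc2ccc(-c3cncn3C3CCN(C(=O)c4ccc(Cl)c(C(F)(F)F)c4)CC3)cc2)c1`: 4.28 nM
- compound 2 `COc1ccc(C(=O)N2CCC(n3cncc3-c3ccc(OS(=O)(=O)c4cccc5cnccc45)cc3)CC2)cc1`: 64 nM
- compound 3 `CN(C)c1ccc(C(=O)N2CCC(n3cncc3-c3ccc(OS(=O)(=O)c4cccc5cnccc45)cc3)CC2)cc1`: 2.19 nM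

Compound 2 gives the highest number of the three; compound 1 is nearest to it and compound 3 furthest, both with markedly lower numbers. Compound 4 `CC(C)c1ccc(C(=O)N2CCC(n3cncc3-c3ccc(OS(=O)(=O)c4cccc5cnccc45)cc3)CC2)cc1` differs from compound 2 by isopropyl in place of methoxy on an aromatic carbon. Among the measured compounds shown here, no measured step covers this exact exchange. For the measured compounds named here, the only step at the same place is a 29-fold lower number from compound 2 to compound 3 (1.47 log units; beyond the scatter), which shows that this position accepts a change and that a change there can move the number a long way. Isopropyl carries no acceptor, so that step is only a loose guide; a lower number than compound 2 is expected for compound 4, likely smaller than the dimethylamino shift, i.e. a 4.3-fold lower number from compound 2 to compound 4 (0.63 log units; beyond the scatter). Compound 4 is thus estimated at 15 nM, within 3 nM to 70 nM.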

Compound 4, half-maximal inhibitory concentration: 37 nM
For compound 4 the middle estimate is 2.5-fold (0.39 log units) below the measured one; the range from low to high includes it.
By their numbers in this assay, from the lowest: compounds 3 and 1 (each within the scatter of the next); then compounds 4 and 2 (each within the scatter of the next).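

In this assay, a 1.7-fold lower number from compound 2 to compound 4 (0.24 log units; within the scatter) leaves isopropyl and methoxy on this aromatic carbon not told apart, so replacing methoxy does not by itself move the number. With a 17-fold higher number from compound 3 to compound 4 (1.23 log units; beyond the scatter), dimethylamino stands alone among the three groups compared here, and the large step at this place belongs to that group. The data shown offer no explanation for this difference.

Open, as far as these compounds go, is whether other nitrogen groups, such as a primary amine, pyrrolidine or morpholine, match dimethylamino on this carbon. Also open, from the compounds shown here alone, is whether dimethylamino gives a similar step on the core of compound 1.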